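Title: From Dipropylamino to a Bromothiophene Methylamine

The source may hold more compounds than are shown below. What is called first, only, known or untested is meant among the compounds shown, and "the series" means these compounds.

The measured compounds in an ADME assay on A549 cells (Homo sapiens) for cytotoxicity, read by resazurin assay, with a stated time of 48 h; a lower number here means that less compound is tolerated, a higher number that more compound is tolerated:
- compound 1, `CC(C)CNc1ccc(NC(=O)c2cc(Cl)ccc2O)c(Cl)c1`: 60000 nM
- compound 2, `CCCCCCCCC(C)Nc1ccc(NC(=O)c2cc(Cl)ccc2O)c(Cl)c1`: 21900 nM
- compound 3, `CCCN(CCC)c1ccc(NC(=O)c2cc(Cl)ccc2O)c(Cl)c1`: 10700 nM

Compound 3 stands lowest of the three numbers in this assay. Its nearest neighbour is compound 2, whose value sits above it by a margin beyond the scatter, and furthest away is compound 1. Going by the values given here, the one step that can be compared directly is a 5.6-fold lower number from compound 1 to compound 3 (0.75 log units; beyond the scatter), a modest lowering that goes with a change of the amino substituent on the shared core.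

Compound 4, `O=C(Nc1ccc(NCc2ccc(Br)s2)cc1Cl)c1cc(Cl)ccc1O`, has not yet been measured. It differs from compound 3 in one place: ((5-bromothiophen-2-yl)methyl)amino in place of dipropylamino on an aromatic carbon

Among the compounds with values here, no measured step covers this particular exchange, since every measured compound carries an open-chain amino group at that position. What the three numbers do show is that changing the amino substituent moves this assay by modest margins, as in the step from compound 1 to compound 3. A step of similar or smaller size is therefore expected for compound 4, in no firmly predictable direction, and the estimate is placed a little below compound 3 with a range wide enough to cover a result in either direction.

The expected step from compound 3 to compound 4 is a 1.3-fold lower number from compound 3 to compound 4 (0.13 log units; within the scatter). Compound 4 is estimated at 8000 nM, with a range from 2500 nM to 25000 nM.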

Compound 4, half-maximal cytotoxic concentration: 20700 nM
Compound 4: the middle estimate sits 2.6-fold (0.41 log units) below what was measured, within the range that was stated.
By their numbers in this assay, from the lowest: compounds 3, 4 and 2 (each within the scatter of the next, the first and the last beyond it); then compound 1.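

In this assay the exchange of dipropylamino for ((5-bromothiophen-2-yl)methyl)amino gives a 1.9-fold higher number from compound 3 to compound 4 (0.29 log units; within the scatter) and so does not separate the two compounds, even though the entering group brings a five-membered aromatic ring with one hetero atom and the leaving group has no ring. Going by these compounds alone, the earlier compounds carried only open-chain amino groups on this aromatic carbon, para to a large group, so this is the first sign that a ring-bearing group there can leave the number in the same region as dipropylamino. Against the isobutylamino group, 5-bromothiophen-2-yl in place of isopropyl gives a 2.9-fold lower number from compound 1 to compound 4 (0.46 log units; beyond the scatter) and points the same way as a 5.6-fold lower number from compound 1 to compound 3 (0.75 log units; beyond the scatter) while nothing measured here accounts for either step.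

On these data alone, what the bromine contributes remains open, as does whether a plain thiophene or a benzyl group on the same nitrogen would give a number close to that of compound 4. As far as these compounds go, it is also open how a chain ending in a carboxylic acid or a morpholine at this position would read in this assay on the shared core.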